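Tellurium Amides: Phenyl to 2-Phenylethenyl on the Carbonyl

This account rests on a few compounds, and the source may have more. Where it says the series, first, only, none or still open, it means among the compounds named here.

Compound 2 `COc1ccc(N(CC(=O)NCCC[Te]c2ccccc2)C(=O)c2ccccc2)cc1` gives 5000 nM in a functional assay on A-431 cells (Homo sapiens) for cytotoxicity, read by MTT assay, with a stated time of 24 h; a lower number here means a stronger inhibitor, a higher number a weaker inhibitor. Its nearest neighbour, compound 1 `COc1ccc(N(CC(=O)NCCC[Te]c2ccccc2)C(=O)CNC(=O)OC(C)(C)C)cc1`, gives 5000 nM in this assay, and the step of no change at the digits printed from compound 1 to compound 2 (within the scatter) left the reading unchanged. Compound 3 `COc1ccc(N(CC(=O)NCCC[Te]c2ccccc2)C(=O)/C=C/c2ccccc2)cc1` carries 2-phenylethenyl in place of phenyl on a carbonyl carbon. Among the compounds with values here, only that one step bears on this change; it shows a large replacement on the same carbonyl carbon moving nothing, and nothing measured speaks to a double bond outside aromatic rings. Compound 3 is expected to sit at the same level, with the step of no change at the digits printed from compound 2 to compound 3 (within the scatter) expected to stay within the scatter. The estimate for compound 3 is 5000 nM, between 2000 nM and 12000 nM.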

Compound 3, half-maximal inhibitory concentration: 6000 nM
The estimate for compound 3 lay 1.2-fold (0.08 log units) below the measured number, within the range that was stated.
By their numbers in this assay, from the lowest: compounds 1, 2 and 3 (each within the scatter of the next).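

In this assay the readings show a 1.2-fold higher number from compound 2 to compound 3 (0.08 log units; within the scatter) and a 1.2-fold higher number from compound 1 to compound 3 (0.08 log units; within the scatter) with the change made on the same carbonyl carbon. This adds a third group at this position, and the first with a double bond outside aromatic rings, yet all three compounds remain within the scatter of one another. Nothing available offers an explanation for this flat reading. The compounds shown leave open whether an amine or a carboxylic acid on this carbonyl carbon would give a different number. They also leave open whether a longer chain there would do so.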